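Benzyl Sulfanyl Swap Carried Onto a Second Core

The compounds below may be only part of what the source reports. "The series", "measured", "known", "first", "only" and "open" are said of these compounds alone.

Three compounds of the series carry a measurement in an ADME assay on microsomes from liver (Homo sapiens) for metabolic stability, read by LC-MS, using NADPH, tested at 5 uM; on this read-out higher numbers stand for a longer-lived compound and lower numbers for a shorter-lived compound. Compound 1 `Cc1cc(-c2ccccc2)n(/C(N)=N/S(=O)(=O)c2cc(C)c(Cl)cc2SCc2cccc(C(F)(F)F)c2)n1` gives 0.169 h. Compound 2 `Cc1cc(-c2ccccc2)n(/C(N)=N/S(=O)(=O)c2cc(C)c(Cl)cc2SCc2ccccc2C)n1` gives 0.154 h. Compound 3 `Cc1cc(S(=O)(=O)/N=C(\N)n2nccc2-c2ccccc2)c(SCc2ccccc2C)cc1Cl` gives 0.0802 h. Compound 4 `Cc1cc(S(=O)(=O)/N=C(\N)n2nccc2-c2ccccc2)c(SCc2cccc(C(F)(F)F)c2)cc1Cl` has not yet been measured in this assay.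

Compound 2 and compound 1 differ in one place: 3-(trifluoromethyl)phenyl in place of 2-methylphenyl on a saturated chain carbon bound to a sulfur. That step is a 1.1-fold higher number from compound 2 to compound 1 (0.04 log units; within the scatter), so the two numbers sit together. Compound 2 and compound 3 share the benzylsulfanyl side chain and differ only in the core: hydrogen in place of methyl on an aromatic carbon. That step reads a 1.9-fold lower number from compound 2 to compound 3 (0.28 log units; within the scatter).

Compound 4 arises from compound 3 by the same change that separates compound 1 from compound 2: 3-(trifluoromethyl)phenyl in place of 2-methylphenyl on a saturated chain carbon bound to a sulfur. The place is described in the same words for both pairs, so the change is the same, made on the core of compound 3 rather than the core of compound 2. Since the measured pair moved only a 1.1-fold higher number from compound 2 to compound 1 (0.04 log units; within the scatter), the same change on compound 3 is expected to move about as little, a 1.1-fold higher number from compound 3 to compound 4 (0.05 log units; within the scatter). For compound 4 in this assay the number is therefore estimated at 0.09 h, with a range from 0.05 h to 0.17 h. This rests on a single matched pair, and the range is set wide accordingly.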

Compound 4, half-life: 0.0863 h
Compound 4: the middle estimate sits 1.0-fold (0.02 log units) above what was measured, and the stated range covers the measured number.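

Notes on the series: in this assay, 3-(trifluoromethyl)phenyl in place of 2-methylphenyl on the core of compound 3 gives a 1.1-fold higher number from compound 3 to compound 4 (0.03 log units; within the scatter), and this agrees with the same change on the core of compound 2: the same change on two cores in this assay, a 1.1-fold higher number (0.04 log units; within the scatter) from compound 2 to compound 1 and a 1.1-fold higher number (0.03 log units; within the scatter) from compound 3 to compound 4, 1.0-fold (0.01 log units) apart, within the scatter of two such steps.

Read the other way around the same four compounds, hydrogen in place of methyl on an aromatic carbon with the 3-(trifluoromethyl)benzyl side chain in place gives a 2.0-fold lower number from compound 1 to compound 4 (0.29 log units; within the scatter), and this agrees with the step measured with the 2-methylbenzyl side chain: the same change on two cores in this assay, a 1.9-fold lower number (0.28 log units; within the scatter) from compound 2 to compound 3 and a 2.0-fold lower number (0.29 log units; within the scatter) from compound 1 to compound 4, 1.0-fold (0.01 log units) apart, within the scatter of two such steps.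

So within these four compounds, the side-chain change and the core change each read alike in both settings, but the side-chain step lies within the scatter on both cores, so its agreement shows only that the change leaves the half-life about where it was, and it does not show that a change with a larger step would carry from one core to the other.

The compounds shown leave open whether the same agreement holds when an amine or a carboxylic acid takes the place of 3-(trifluoromethyl)phenyl, or when a longer chain joins the ring to the sulfur. They also leave open whether it extends to any core beyond the two shown here.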